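This account rests on a few compounds, and the source may have more. Where it says the series, first, only, none or still open, it means among the compounds named here.

Compound 3 `Cc1cc(C)n(CCOC2CC(=O)Nc3c2c(C)nn3-c2ncnc3nc[nH]c23)n1` carries the shared core with a 2-(3,5-dimethyl-1H-pyrazol-1-yl)ethyl on an oxygen on a saturated carbon. In a functional assay on HEK293 cells for agonist activity at G-protein coupled receptor 39 (Homo sapiens), read by scintillation proximity assay and inositol phosphate accumulation, with a stated time of 75 min, in the presence of a further agent that is not named here (a higher number here means that more compound is needed for the effect, a lower number that less compound is needed), compound 3 gives 16 nM, the highest of the three numbers measured. Compound 1 `Cc1nn(-c2ncnc3nc[nH]c23)c2c1C(OC1CCCC1)CC(=O)N2` gives 2 nM in this assay, and compound 2 `Cc1nn(-c2ncnc3nc[nH]c23)c2c1C(OCCc1ccccc1)CC(=O)N2` gives 3 nM; the step of an 8.0-fold higher number from compound 1 to compound 3 (0.90 log units; beyond the scatter) and the step of a 5.3-fold higher number from compound 2 to compound 3 (0.73 log units; beyond the scatter) both place compound 3 above its neighbours, while the step of a 1.5-fold higher number from compound 1 to compound 2 (0.18 log units; within the scatter) is within the scatter.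

Compound 4 `Cc1nn(-c2ncnc3nc[nH]c23)c2c1C(OCCn1cccn1)CC(=O)N2` differs from compound 3 in one place: 1H-pyrazol-1-yl in place of 3,5-dimethyl-1H-pyrazol-1-yl on a saturated chain carbon, two bonds along the chain from an oxygen on a saturated carbon. Among the compounds with values here, no measured step removes methyl groups from the pyrazole, so the nearest guide is the step from compound 2 to compound 3, which swapped phenyl for the dimethylated pyrazole at that position. A pyrazole without methyls may sit between those two cases, so a change of modest size toward a lower number, or none beyond the scatter, is expected in this assay. The step expected for compound 4 is a 1.3-fold lower number from compound 3 to compound 4 (0.12 log units; within the scatter), and its value in this assay is estimated at 12 nM, within 5 nM to 30 nM.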

Compound 4, half-maximal effective concentration: 16 nM
Estimate against measurement, compound 4: 1.3-fold (0.12 log units) below; low and high end bracket the measured number.
By their numbers in this assay, from the lowest: compounds 1 and 2 (each within the scatter of the next); then compounds 3 and 4 (each within the scatter of the next).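

In this assay, taking both methyl groups off the pyrazole on a saturated chain carbon, two bonds along the chain from an oxygen on a saturated carbon, gives no change at the digits printed from compound 3 to compound 4 (within the scatter) and so leaves the number unmoved. The higher number therefore does not depend on those methyl groups, since the 1H-pyrazol-1-yl compound still shows a 5.3-fold higher number from compound 2 to compound 4 (0.73 log units; beyond the scatter) and an 8.0-fold higher number from compound 1 to compound 4 (0.90 log units; beyond the scatter), the same gaps as its dimethylated counterpart. Nothing available explains why the pyrazole-bearing compounds stand apart from those with phenyl or cyclopentyl.

Still open, on these data alone, is whether a pyridin-2-yl or an imidazol-1-yl on the same chain would stay with the pyrazoles or move toward the phenyl compound. As far as these compounds go, it is also open whether a longer chain carrying the 1H-pyrazol-1-yl would change the number.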